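The source may hold more compounds than are shown below. What is called first, only, known or untested is meant among the compounds shown, and "the series" means these compounds.

Compound 1: `O=S(=O)(c1ccc(Cl)cc1)c1n[nH]c2cc(N3CCNCC3)ccc12` — 110 nM
Compound 2: `CN1CCN(c2ccc3[nH]nc(S(=O)(=O)c4ccccc4Cl)c3c2)CC1` — 4 nM

Both numbers come from an assay on HeLa cells for displacement of a labelled ligand from 5-hydroxytryptamine receptor 6 (Homo sapiens); a lower number here means a stronger inhibitor, a higher number a weaker inhibitor. Among the two values, compound 1 stands at the highest number; the nearest is compound 2, whose number lies far lower, and that gap is beyond the usual scatter. Compound 2 differs from compound 1 in more than one place, so its value does not isolate any single change.

Compound 3, `Cc1ccc(S(=O)(=O)c2n[nH]c3cc(N4CCNCC4)ccc23)cc1`, has not yet been measured. It differs from compound 1 in a single spot: methyl in place of chloro on an aromatic carbon. The chloro group leaves and a methyl group enters, on an aromatic carbon of a six-membered aromatic ring of carbon only, para to a large group. For the measured compounds named here, no measured pair shows this swap on its own, so the expectation rests on the change itself. The step from compound 1 to compound 3 in this assay is expected to be small, estimated as a 1.4-fold higher number from compound 1 to compound 3 (0.13 log units; within the scatter), pointing toward a slightly higher number but not clearly beyond the scatter. Compound 3 is therefore estimated at 150 nM, within a range from 50 nM to 500 nM.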

Compound 3, inhibition constant: 27 nM
Compound 3: the middle estimate sits 5.6-fold (0.74 log units) above what was measured; the measured number lies below the stated range.
By their numbers in this assay, from the lowest: compound 2; then compound 3; then compound 1.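

In this assay, putting methyl in place of chloro on this aromatic carbon, para to a large group, gives a 4.1-fold lower number from compound 1 to compound 3 (0.61 log units; beyond the scatter), so a swap of one heavy atom for another at this spot is enough to move the number beyond the usual scatter. Compound 1 and compound 2 differ in more than one place and could not tie a change in the number to any single group, whereas this pair changes only 4-chlorophenyl to 4-methylphenyl and so isolates that one difference. Nothing available here explains why the methyl compound gives the lower number, so the step stands as an observation without a known cause.

The compounds shown leave open how a methoxy group, a fluoro group or a longer chain such as ethyl would behave on this same aromatic carbon, and so whether the number keeps falling or turns back up with other groups there. They also leave open whether the swap from chloro to methyl would give a step of similar size if other parts of the molecule were different.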